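This account rests on a few compounds, and the source may have more. Where it says the series, first, only, none or still open, it means among the compounds named here.

Compounds measured in an assay on T47D cells for inhibition of 17-beta-hydroxysteroid dehydrogenase type 1 (Homo sapiens), read by HPLC, with a stated time of 24 h; a lower number here means a stronger inhibitor, a higher number a weaker inhibitor:
Compound 1 `Cc1ccccc1N(C)C(=O)c1ccc(-c2ccc(O)cc2)o1` gives 21 nM.
Compound 2 `Cc1ccccc1N(C)C(=O)c1ccc(-c2ccc(O)c(Cl)c2)o1` gives 52 nM.

Compound 1 holds the lower of the two numbers; its closest neighbour is compound 2, with a 2.5-fold higher number from compound 1 to compound 2 (0.39 log units; beyond the scatter). Compound 3 `Cc1cccc(F)c1N(C)C(=O)c1ccc(-c2ccc(O)cc2)o1` is not yet measured. It differs from compound 1 by fluoro in place of hydrogen on an aromatic carbon. Among the measured compounds shown here, the only measured step, the chloro addition from compound 1 to compound 2, sits on a different ring, so it bears only loosely here. From the compounds shown here alone, a halogen added elsewhere on the core cost modestly; on this ring the effect is unknown. Compound 3 is therefore expected to show a 1.2-fold higher number from compound 1 to compound 3 (0.08 log units; within the scatter), giving an estimated 25 nM with a range of 8 nM to 80 nM.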

Compound 3, half-maximal inhibitory concentration: 120 nM
Beside the measured number, compound 3's estimate is 4.8-fold (0.68 log units) below it, and the stated range ends below it.
By their numbers in this assay, from the lowest: compound 1; then compound 2; then compound 3.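

Among the compounds shown here, with the change from 2-methylphenyl to 2-fluoro-6-methylphenyl, the single fluoro gives a 5.7-fold higher number from compound 1 to compound 3 (0.76 log units; beyond the scatter), which shows that this ring, unchanged in the earlier compounds, does not accept even this one-atom addition without loss. Compound 1 keeps the lowest number of the three, and no measurement on hand accounts for the change at this position. The compounds shown leave open whether a chloro or methoxy group at this same place would follow fluoro. They also leave open whether other places on this ring respond in the same way.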